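This account rests on a few compounds, and the source may have more. Where it says the series, first, only, none or still open, it means among the compounds named here.

In a functional assay on HOS-TE85 cells (Homo sapiens) for inhibition, read by CCK-8 assay, with a stated time of 72 h (a higher number here means a weaker inhibitor, a lower number a stronger inhibitor), compound 2 `CCN1C(=O)CSC1c1cccc(C(=O)NCCCCc2ccccc2)c1` gives > 1000 nM, which is a limit and not a number. Compound 1 `CC(C)(C)c1conc1N1C(=O)CSC1c1cccc(C(=O)NCCCCc2ccccc2)c1` gives > 1000 nM, also a limit, even though it carries a five-membered aromatic ring on that same amide-type nitrogen in a ring. Together they mark (the limit of > 1000 nM in this assay, at which 2 of the 3 values shown sit). For the measured compounds named here, the one measured step at this place is a step that the two limits leave unreadable from compound 1 to compound 2, so it offers no size to go by. Going by the values given here, compound 3 `O=C(NCCCCn1cccn1)c1cccc(C2SCC(=O)N2c2cc(Cl)ccn2)c1` gives 36.4 nM, yet no single-place step ties it to the others. Compound 4 `O=C(NCCCCc1ccccc1)c1cccc(C2SCC(=O)N2c2ccccc2F)c1` has 2-fluorophenyl in place of ethyl on an amide-type nitrogen in a ring. Only a modest gain in strength is therefore expected, an at least 1.2-fold lower number from compound 2 to compound 4 (0.09 log units; that floor lies within the scatter). Compound 4 is estimated at 800 nM, within 150 nM to 4000 nM, and may again report only a limit.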

Compound 4, half-maximal inhibitory concentration: 34.1 nM
Beside the measured number, compound 4's estimate is 23-fold (1.37 log units) above it, outside the stated range (below it).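

For the compounds shown here, on the amide-type nitrogen in a ring, the choice of group clearly matters: 2-fluorophenyl in place of ethyl gives an at least 29-fold lower number from compound 2 to compound 4 (1.46 log units; beyond the scatter), the first step here with a readable size. Putting 2-fluorophenyl in place of the group with a five-membered aromatic ring gives an at least 29-fold lower number from compound 1 to compound 4 (1.46 log units; beyond the scatter), so carrying an aromatic ring here is not enough; which ring matters. Both steps start from a limit, so each gives only a floor: the limit of > 1000 nM in this assay, at which 2 of the 4 values shown sit.

The compounds shown leave open whether the fluorine contributes, which plain phenyl would test. Whether a pyridine ring or a benzyl group also works here is open too.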